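The source may report more compounds than this note shows. Statements on the series, on what has been measured and on what is new or still open speak of the compounds shown alone.

Compound 1 `COc1cc(NC(C)CCCNC(=O)Nc2ccc(Br)cc2)c2ncccc2c1`: 25000 nM
Compound 2 `COc1cc(NC(C)CCCNC(=O)NNC(=O)Nc2ccc(F)cc2)c2ncccc2c1`: >= 250000 nM (a limit)
Compound 3 `COc1cc(NC(C)CCCNC(=O)NNC(=O)Nc2cccc(F)c2)c2ncccc2c1`: >= 250000 nM (a limit)

All three values come from a functional assay on MOLT-4 cells (Homo sapiens) for inhibition, read by MTT assay, with a stated time of 72 h; a higher number here means a weaker inhibitor, a lower number a stronger inhibitor. Compound 3 stands only at a limit, >= 250000 nM, and this is the limit of >= 250000 nM in this assay, at which 2 of the 3 values shown sit.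

Compound 4 `COc1cc(NC(C)CCCNC(=O)Nc2ccc(C(F)(F)F)cc2)c2ncccc2c1` differs from it as follows: 4-(trifluoromethyl)phenyl in place of ((3-fluorophenyl)carbamoyl)amino on an amide-type nitrogen. Here 4-(trifluoromethyl)phenyl replaces ((3-fluorophenyl)carbamoyl)amino on an amide-type nitrogen, the place where compound 1 carries 4-bromophenyl.

Within the data shown here, two measured steps bear on this change: an at least 10-fold higher number from compound 1 to compound 2 (1.00 log units; beyond the scatter) and an at least 10-fold higher number from compound 1 to compound 3 (1.00 log units; beyond the scatter). Both lie beyond the scatter, and the change to compound 4 runs the opposite way, so a lower number of similar size is expected. The expected step is an at least 12-fold lower number from compound 3 to compound 4 (1.09 log units; beyond the scatter). For compound 4 the estimate is 20000 nM, with an expected range of 5000 nM to 80000 nM.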

Compound 4, half-maximal inhibitory concentration: 20000 nM
For compound 4 middle estimate and measured number coincide at the digits printed, and the stated range covers the measured number.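

With 4-(trifluoromethyl)phenyl on the amide-type nitrogen, the steps are an at least 12-fold lower number from compound 3 to compound 4 (1.09 log units; beyond the scatter) and an at least 12-fold lower number from compound 2 to compound 4 (1.09 log units; beyond the scatter), so the gain seen with compound 1 is not confined to its bromo group. The values of compound 2 and compound 3 are limits: the limit of >= 250000 nM in this assay, at which 2 of the 4 values shown sit.

Trifluoromethyl in place of bromo gives a 1.3-fold lower number from compound 1 to compound 4 (0.10 log units; within the scatter), so these two groups cannot be told apart here.

Still open, as far as these compounds go, is whether an amine or a carboxylic acid on that aromatic ring would fit the same picture, and whether a longer chain would change it.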